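A few compounds are considered here, and "the series" means these few. Any claim that something is new, unique, unknown or untested is made for them only; others in the source may bear on it.

Of the compounds shown here, three have been measured in an assay on isolated protein for inhibition of Amine oxidase [flavin-containing] B (Homo sapiens); a lower number here means a stronger inhibitor, a higher number a weaker inhibitor. Compound 1 `CC(C)=CCOc1ccc(C(=O)/C=C/c2ccc(C)cc2)c(O)c1` gives 1030 nM, compound 2 `COc1ccc(C(=O)/C=C/c2ccc(OCc3ccccc3)cc2)cc1` gives 450 nM, and compound 3 `O=C(/C=C/c1ccc(Cl)cc1)c1ccccc1O` gives 160 nM, the lowest of the three numbers; compound 2 lies nearest above it and compound 1 furthest, both gaps beyond the scatter. Compound 4 `O=C(/C=C/c1ccc(Cl)cc1)c1ccc(F)cc1O` has not yet been measured in this assay. It differs from compound 3 in one place: fluoro in place of hydrogen on an aromatic carbon, a change that sits meta to a hydroxy group and para to a large group. Among the measured compounds shown here, no measured pair of this kind exists to go by, so one expects no step beyond the scatter, at most a small shift in either direction. The expected step is a 1.1-fold lower number from compound 3 to compound 4 (0.03 log units; within the scatter) in this assay. Compound 4 is expected to give about 150 nM, within 50 nM to 450 nM.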

Compound 4, half-maximal inhibitory concentration: 71 nM
Estimate against measurement, compound 4: 2.1-fold (0.32 log units) above, and the stated range covers the measured number.
By their numbers in this assay, from the lowest: compound 4; then compound 3; then compound 2; then compound 1.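

Fluoro in place of hydrogen on an aromatic carbon, meta to a hydroxy group and para to a large group, brings a 2.3-fold lower number from compound 3 to compound 4 (0.35 log units; beyond the scatter) in this assay and so shows that this position responds to a single added atom. The step is modest, but it is the only one-place comparison among these compounds. No measurement shown here explains the step. Going by these compounds, whether chloro, methoxy or an amine at this position would give a similar step remains open, as does whether fluoro elsewhere on this ring would.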